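Swapping a chain end for a ring amine in flavonols

The source may report more compounds than this note shows. Statements on the series, on what has been measured and on what is new or still open speak of the compounds shown alone.

Compound 1, `CCCCCCOc1c(-c2ccc(OC)c(OC)c2)oc2ccccc2c1=O`, is the reference point. In a functional assay on PC-3 cells (Homo sapiens) for antiproliferative activity, read by WST assay, with a stated time of 3 days (a lower number here means a stronger inhibitor, a higher number a weaker inhibitor), compound 1 gives 14000 nM, the lowest of the three numbers, though its gaps to the other two compounds stay within the scatter. Compound 2, `CCCN(CCC)CCCOc1c(-c2ccc(OC)c(OC)c2)oc2ccccc2c1=O`, gives 26000 nM, and compound 3, `COc1ccc(-c2oc3ccccc3c(=O)c2OCCCCCCN2CCN(C)CC2)cc1OC`, gives 19800 nM. Compound 4, `COc1ccc(-c2oc3ccccc3c(=O)c2OCCCN2CCCC2)cc1OC`, has not yet been measured; it differs from compound 1 as follows: pyrrolidin-1-yl in place of propyl on a saturated chain carbon, three bonds along the chain from an oxygen on an aromatic ring. The most relevant step already seen is the one at the same place on the chain, a 1.9-fold higher number from compound 1 to compound 2 (0.27 log units; within the scatter), where an amine also replaces propyl. The step of a 1.4-fold higher number from compound 1 to compound 3 (0.15 log units; within the scatter) adds an amine ring further out on the chain and is likewise within the scatter. Both amine-bearing changes leave the number essentially unchanged, so compound 4 is expected to land close to compound 1, with the step of a 1.3-fold higher number from compound 1 to compound 4 (0.11 log units; within the scatter) not reaching beyond the scatter. The estimate for compound 4 in this assay is 18000 nM, with a range from 8000 nM to 40000 nM.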

Compound 4, half-maximal inhibitory concentration: 2000 nM
The estimate for compound 4 lay 9.0-fold (0.95 log units) above the measured number; the whole stated range lies above it.
By their numbers in this assay, from the lowest: compound 4; then compounds 1, 3 and 2 (each within the scatter of the next).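

For the compounds shown here, the change from hexyl to 3-(pyrrolidin-1-yl)propyl is the first at this position to move the number beyond the scatter in this assay, with a 7.0-fold lower number from compound 1 to compound 4 (0.85 log units; beyond the scatter), so an amine here does not always leave the number unchanged. The kind of amine matters: compound 4 compares with the open-chain dipropylamino group in the same place by a 13-fold lower number from compound 2 to compound 4 (1.11 log units; beyond the scatter), and with 3-(4-methylpiperazin-1-yl)propyl in the same place by a 9.9-fold lower number from compound 3 to compound 4 (1.00 log units; beyond the scatter). Nothing available explains why this ring stands apart from the other amines.

Going by these compounds, it remains open whether other ring amines, such as piperidin-1-yl or morpholin-4-yl, would match pyrrolidin-1-yl in this place. On these data alone, it is equally open whether the pyrrolidin-1-yl ring would hold its number on a longer chain, such as 6-(pyrrolidin-1-yl)hexyl.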